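A few compounds are considered here, and "the series" means these few. Any claim that something is new, unique, unknown or untested is made for them only; others in the source may bear on it.

Of the compounds shown here, three have been measured in a functional assay on HeLa cells (Homo sapiens) for antiproliferative activity, read by MTT assay, with a stated time of 48 h (a lower number here means a stronger inhibitor, a higher number a weaker inhibitor), so far. Compound 1 `Cc1ccc2nc(NC(c3cn(-c4ccccc4)nc3-c3cccc([N+](=O)[O-])c3)c3c(O)ccc4ccccc34)sc2c1` gives 7360 nM and compound 2 `Cc1ccc2nc(NC(c3cn(-c4ccccc4)nc3-c3cccc(Cl)c3)c3c(O)ccc4ccccc34)sc2c1` gives 9430 nM in this test. Compound 3 `COc1cccc(-c2nn(-c3ccccc3)cc2C(Nc2nc3ccccc3s2)c2c(O)ccc3ccccc23)c1` gives 14900 nM as its value. That places compound 3 within the scatter of compound 2, while its number is higher than that of compound 1 by only slightly more than the scatter.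

Compound 4 `Cc1ccc(-c2nn(-c3ccccc3)cc2C(Nc2nc3ccccc3s2)c2c(O)ccc3ccccc23)cc1` has 4-methylphenyl in place of 3-methoxyphenyl on an aromatic carbon of compound 3: 4-methylphenyl in place of 3-methoxyphenyl on an aromatic carbon. Within the data shown here, only one measured step offers a guide, a swap of chloro in place of nitro on an aromatic carbon: a 1.3-fold higher number from compound 1 to compound 2 (0.11 log units; within the scatter). Among the measured compounds shown here, it is a small step, and no measured compound carries 4-methylphenyl, so the guidance is indirect. In this assay no change beyond the scatter is therefore expected, and no direction is firmly expected either. The expected step is a 1.1-fold lower number from compound 3 to compound 4 (0.06 log units; within the scatter) and remains an estimate. For compound 4 the estimated value is 13000 nM with an expected range from 5500 nM to 30000 nM.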

Compound 4, half-maximal inhibitory concentration: 8050 nM
Beside the measured number, compound 4's estimate is 1.6-fold (0.21 log units) above it; the range from low to high includes it.
By their numbers in this assay, from the lowest: compounds 1, 4, 2 and 3 (each within the scatter of the next, the first and the last beyond it).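

In this assay, replacing 3-methoxyphenyl with 4-methylphenyl on the five-membered aromatic ring gives a 1.9-fold lower number from compound 3 to compound 4 (0.27 log units; within the scatter), so this exchange of a whole substituted ring stays within the usual scatter. The earlier step swapped only chloro for nitro on an aromatic carbon, whereas this one changes both the substituent on the phenyl ring and where it sits, and it removes a hydrogen-bond acceptor without moving the result beyond the scatter. No measured property of these groups is available to explain this result.

The two changes made in this swap cannot be separated, and a 4-methoxyphenyl or 3-methylphenyl group would be needed to tell them apart. Going by these compounds, how an amine, a carboxylic acid or a longer chain on this phenyl ring would behave also remains open.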